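Chloro in place of hydrogen on compound 2

A few compounds are considered here, and "the series" means these few. Any claim that something is new, unique, unknown or untested is made for them only; others in the source may bear on it.

Measured in a functional assay on NCI-H522 cells (Homo sapiens) for inhibition, with a stated time of 48 h; on this read-out lower numbers stand for stronger inhibition of growth and higher numbers for weaker inhibition of growth:
- compound 1 `COc1c(C(=O)/C=C/c2ccc(Cl)cc2)c(O)c(Br)c2occc12`: 2800 nM
- compound 2 `C=CCc1c(O)c(C(=O)/C=C/c2ccccc2)c(OC)c2ccoc12`: 2150 nM

Compound 2 lies within the scatter of compound 1, so these two values set no order. Compound 3 `C=CCc1c(O)c(C(=O)/C=C/c2ccc(Cl)cc2)c(OC)c2ccoc12` differs from compound 2 by chloro in place of hydrogen on an aromatic carbon, para to a large group (chloro in place of hydrogen on an aromatic carbon). Among the compounds with values here, no measured pair isolates this change. Compound 1 also bears 4-chlorophenyl and gives 2800 nM, so no step beyond the scatter is expected in this assay. The estimated change is small, a 1.1-fold lower number from compound 2 to compound 3 (0.03 log units; within the scatter). For compound 3 the estimated value is 2000 nM, with an expected range of 900 nM to 4500 nM.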

Compound 3, concentration for 50% growth inhibition: 1880 nM
Compound 3: the middle estimate sits 1.1-fold (0.03 log units) above what was measured; measured number inside the range.
By their numbers in this assay, from the lowest: compounds 3, 2 and 1 (each within the scatter of the next).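

Chloro in place of hydrogen on the aromatic carbon, para to a large group, can now be read directly in this assay: the step is a 1.1-fold lower number from compound 2 to compound 3 (0.06 log units; within the scatter). With 4-chlorophenyl held in both compounds, allyl in place of bromo gives a 1.5-fold lower number from compound 1 to compound 3 (0.17 log units; within the scatter), so neither change separates the compounds on this read-out. No evidence bears on these results.

As far as these compounds go, whether an amine or a carboxylic acid in place of chloro would give a step beyond the scatter remains open. The same holds for a longer chain in place of allyl.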